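Aryl variation at the triazole of the trimethoxyphenyl series

The source may report more compounds than this note shows. Statements on the series, on what has been measured and on what is new or still open speak of the compounds shown alone.

compound 1 `COc1cc(-n2ncnc2-c2ccc(OC(C)C)cc2)cc(OC)c1OC`: 800 nM
compound 2 `COc1cc(-n2ncnc2-c2ccc(C)cc2)cc(OC)c1OC`: > 10000 nM
compound 3 `COc1cc(-c2ncnn2-c2ccc(Cl)cc2Cl)cc(OC)c1OC`: > 10000 nM

In a functional assay on K562 cells (Homo sapiens) for antiproliferative activity, read by MTT assay, with a stated time of 72 h (a lower number here means a stronger inhibitor, a higher number a weaker inhibitor), compound 1 gives 800 nM. For compound 2 the assay returns only its limit, > 10000 nM. Compound 3 likewise returns only the limit, > 10000 nM. Compound 2 thus stands at the limit of > 10000 nM in this assay, at which 2 of the 3 values shown sit, with no number of its own. Within the data shown here, the one measured step at this position, an at least 12-fold higher number from compound 1 to compound 2 (1.09 log units; beyond the scatter), shows that changing the group on the pendant phenyl can shift the result strongly.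

Compound 4 `COc1cc(-n2ncnc2-c2cccc(Cl)c2)cc(OC)c1OC` differs from compound 2 by 3-chlorophenyl in place of 4-methylphenyl on an aromatic carbon. Among the measured compounds shown here, no measured pair tells whether a chlorine placed this way recovers potency. Compound 4 is therefore expected to remain at or near the limit, a number no higher from compound 2 to compound 4 (the limit leaves the size open). The estimate for compound 4 is 10000 nM, between 3000 nM and 30000 nM.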

Compound 4, half-maximal inhibitory concentration: > 10000 nM
Compound 4 gave a limit, no number (the forecaster's own chance of this, stated with the estimate: 65%); the middle value lies on the limit itself.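

Among these compounds, compound 2 and compound 4 both return only a limit, so no step between them can be read: the limit of > 10000 nM in this assay, at which 3 of the 4 values shown sit. From the compounds shown here alone, how far apart these two compounds lie stays open, as does whether any pendant group other than that of compound 1 gives a number.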